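This account rests on a few compounds, and the source may have more. Where it says the series, first, only, none or still open, it means among the compounds named here.

For the measured compounds named here, compound 2 `C/N=C(/NC#N)NCCCCn1nc(-c2ccc(C)cc2)ccc1=O` holds the higher of the two numbers measured so far in a functional assay on the whole organism with Rattus norvegicus as the target, at a dose of 100 mg/kg; on this read-out lower numbers stand for less inhibition and higher numbers for more inhibition at the one dose given (going by the name of the read-out): compound 2 gives 45.7%, while compound 1 `C/N=C(/NC#N)NCCCCn1nc(N(C)C)ccc1=O` gives 26.3%. Going by the values given here, the one measured step, a number 19.4 percentage points higher from compound 1 to compound 2 (beyond the scatter), shows that the group on this aromatic carbon matters for the read-out. Compound 3 `C/N=C(/NC#N)NCCCCn1nc(N2CCN(C)CC2)ccc1=O` is compound 2 altered at that same place: 4-methylpiperazin-1-yl in place of 4-methylphenyl on an aromatic carbon. Among the compounds with values here, no measured step covers a 4-methylpiperazin-1-yl group, so the step from compound 1 to compound 2 is the only guide; there, the dimethylamino group went with the lower number and the 4-methylphenyl with the higher one, and compound 3 again carries a nitrogen-bearing group, as compound 1 does. A fall back toward compound 1 is therefore expected, of uncertain size, with the estimated step being a number 15.7 percentage points lower from compound 2 to compound 3 (beyond the scatter). Compound 3 is expected to give 30% in this assay, within a range from 15% to 48%.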

Compound 3, a percentage reported as inhibition, in the whole organism at one dose (the size of the read-out at that dose, not a potency): 7.9%
Compound 3: middle estimate off by 22.1 percentage points, on the high side, outside the stated range (below it).
By their numbers in this assay, from the lowest: compound 3; then compound 1; then compound 2.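

In this assay the change from 4-methylphenyl to 4-methylpiperazin-1-yl gives a number 37.8 percentage points lower from compound 2 to compound 3 (beyond the scatter), the largest step yet seen at this aromatic carbon, although both groups have 7 heavy atoms. The earlier compounds shown here could suggest that a nitrogen-bearing group here simply returns the number to that of compound 1, but the two nitrogen-bearing groups also differ, with a number 18.4 percentage points lower from compound 1 to compound 3 (beyond the scatter), so the order from lowest to highest is 4-methylpiperazin-1-yl, dimethylamino, 4-methylphenyl. Nothing available explains why these groups differ.

As far as these compounds go, it remains open whether a morpholin-4-yl or piperidin-1-yl ring at this carbon would stay as low as compound 3. An unsubstituted phenyl or a 4-methoxyphenyl group would show whether compound 2 depends on its methyl group.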